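Swapping a chlorophenyl group for a phenethyl chain

The source may report more compounds than this note shows. Statements on the series, on what has been measured and on what is new or still open speak of the compounds shown alone.

Compound 3, `CCC1(Cc2ccccc2)OS(=O)(=O)C=C1OCc1cccc(Cl)c1`, gives 50000 nM in an ADME assay on HEL cells (Homo sapiens) for cytotoxicity, with a stated time of 3 days (on this read-out lower numbers stand for higher toxicity in this test and higher numbers for lower toxicity in this test), the lowest of the two plain numbers shown; its nearest neighbour is compound 1, `CCC1(Cc2ccccc2)OS(=O)(=O)C=C1OCCCCc1ccccc1`, which gives 99000 nM, a gap that sits within the scatter. Compound 2, `CCC1(Cc2ccccc2)OS(=O)(=O)C=C1OCc1ccc(Cl)cc1`, gives > 200000 nM in this assay, which is a limit rather than a number. Compound 4, `CCC1(Cc2ccccc2)OS(=O)(=O)C=C1OCCCc1ccccc1`, has not been tested; it differs from compound 3 by phenethyl in place of 3-chlorophenyl on a saturated chain carbon bound to an oxygen on an unsaturated carbon. Among the compounds with values here, two measured steps bear on this change. a 2.0-fold lower number from compound 1 to compound 3 (0.30 log units; within the scatter) was within the scatter, and compound 4 carries a chain of the same kind as compound 1. an at least 4.0-fold lower number from compound 2 to compound 3 (0.60 log units; beyond the scatter) lay beyond the scatter, but it compared two chlorophenyl groups, neither of which compound 4 keeps. Returning from an aryl group to a chain is therefore expected to move the number back toward that of compound 1, a step no larger than the scatter. The expected step is a 1.6-fold higher number from compound 3 to compound 4 (0.20 log units; within the scatter). Compound 4 is estimated at 80000 nM, with a range from 30000 nM to 200000 nM.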

Compound 4, half-maximal cytotoxic concentration: 133000 nM
Compound 4: middle estimate off by 1.7-fold (0.22 log units), on the low side; the range from low to high includes it.
By their numbers in this assay, from the lowest: compounds 3, 1 and 4 (each within the scatter of the next, the first and the last beyond it). At a limit, above all of these: compound 2.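

In this assay, the change gives a 2.7-fold higher number from compound 3 to compound 4 (0.42 log units; beyond the scatter), so phenethyl clears the scatter against 3-chlorophenyl, which the 3-phenylpropyl chain of compound 1 did not do. The two chains themselves stay close, with a 1.3-fold higher number from compound 1 to compound 4 (0.13 log units; within the scatter), so the length of the chain makes no readable difference across this pair. Against the 4-chlorophenyl group, the step has only a floor, an at least 1.5-fold lower number from compound 2 to compound 4 (0.17 log units; that floor lies within the scatter), and that floor stays within the scatter, since the value for that group is a limit and not a number: the limit of > 200000 nM in this assay, at which 1 of the 4 values shown sits.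

The compounds shown leave open how a chain ending in an amine or a carboxylic acid would read at this position. They also leave open whether a plain benzyl group, with no chlorine on its ring, would sit with the chains or with the 3-chlorophenyl compound.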